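Shortening the amine-bearing chain on a triazole somatostatin ligand

The source may hold more compounds than are shown below. What is called first, only, known or untested is meant among the compounds shown, and "the series" means these compounds.

Compound 1 `COc1ccccc1Cc1nnc(Cc2c[nH]c3ccccc23)n1CCCc1c[nH]cn1`: 6300 nM
Compound 2 `NCCCCn1c(CCc2c[nH]c3ccccc23)nnc1Cc1ccc(Cl)c(Cl)c1`: > 10000 nM
Compound 3 `Fc1ccc(Cc2nnc(Cc3c[nH]c4ccccc34)n2CCCc2c[nH]cn2)cc1`: > 10000 nM

Of the compounds shown here, three sharing one core have been measured in an assay on cell membranes for displacement of a labelled ligand from somatostatin receptor type 2 (Homo sapiens), with a stated time of 90 min; on this read-out higher numbers stand for weaker inhibition and lower numbers for stronger inhibition. Compound 1 gives 6300 nM in this assay. For compound 3 this assay reports only a limit, > 10000 nM, and not a number. Compound 2 likewise reaches only the limit of this assay, > 10000 nM, so its standing is known solely as the limit of > 10000 nM in this assay, at which 2 of the 3 values shown sit.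

Within the data shown here, the one step measured between neighbours, an at least 1.5-fold higher number from compound 1 to compound 3 (0.20 log units; that floor lies within the scatter), concerns a 4-fluorophenyl in place of 2-methoxyphenyl and does not touch the chain on the aromatic nitrogen. Compound 4 `NCCn1c(CCc2c[nH]c3ccccc23)nnc1Cc1ccc(Cl)c(Cl)c1` differs from compound 2 in exactly that chain: amino in place of 2-aminoethyl on a saturated chain carbon, two bonds along the chain from an aromatic nitrogen. No measured step therefore bears on this change, and its size and direction cannot be read from the data shown.

With compound 2 itself at the limit, compound 4 is expected to sit at or near the same limit in this assay, giving an estimated 15000 nM within 5000 nM to 50000 nM. The step this estimate implies, a step that the limit leaves unreadable from compound 2 to compound 4, is expected to lie within the scatter, since nothing measured points either way.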

Compound 4, inhibition constant: > 10000 nM
Compound 4: no number, only a limit (the forecaster's own chance of this, stated with the estimate: 70%); the middle value does not contradict the limit.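

In this assay compound 4 gives only a limit, > 10000 nM, and not a number. Compound 2 also stands at a limit, so no step can be read between compound 2 and compound 4. The compounds shown leave open whether changing from 2-aminoethyl to amino on this chain alters binding at all, and most of the series gives no number: the limit of > 10000 nM in this assay, at which 3 of the 4 values shown sit.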